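This account rests on a few compounds, and the source may have more. Where it says the series, first, only, none or still open, it means among the compounds named here.

Series notes, cytotoxicity screen.

Two compounds carry a value in an ADME assay on CHO-K1 cells (Cricetulus griseus) for cytotoxicity, read by MTT assay, with a stated time of 24 h; on this read-out lower numbers stand for stronger inhibition and higher numbers for weaker inhibition. Compound 1 `CCCCCCCCCCCCn1nnc(-c2cc([N+](=O)[O-])cc([N+](=O)[O-])c2)n1` returns only a limit of the assay in this assay, > 200000 nM. Among the compounds with values here, compound 2 `O=[N+]([O-])c1cc(-c2nnn(Cc3ccc(Cl)cc3)n2)cc([N+](=O)[O-])c1` gives 170000 nM in this assay, and this is the single actual number in the set; the other entry is the limit of > 200000 nM in this assay, at which 1 of the 2 values shown sits, so compound 2 cannot be placed higher or lower than anything else that was measured.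

Compound 3 `O=[N+]([O-])c1cc(-c2nnn(Cc3cccc(F)c3)n2)cc([N+](=O)[O-])c1` is the next member. Against compound 2 the change is 3-fluorophenyl in place of 4-chlorophenyl on a saturated chain carbon bound to an aromatic nitrogen. Within the data shown here, no measured pair in the set differs in one place, so no step is available to weigh this change. The expected step from compound 2 to compound 3 in this assay is a 1.2-fold higher number from compound 2 to compound 3 (0.07 log units; within the scatter), not beyond the usual scatter in either direction. On that basis compound 3 is expected to give about 200000 nM in this assay, within 100000 nM to 400000 nM, with a fair chance that the assay again reports only a limit.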

Compound 3, half-maximal inhibitory concentration: 315000 nM
Estimate against measurement, compound 3: 1.6-fold (0.20 log units) below; measured number inside the range.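

In this assay, within the data shown here, the pair offers the first readable step at this position: a 1.9-fold higher number from compound 2 to compound 3 (0.27 log units; within the scatter). Replacing 4-chlorophenyl with 3-fluorophenyl on a saturated chain carbon bound to an aromatic nitrogen therefore leaves the read-out within the usual scatter, and compound 3, like compound 2, returns an actual number. Compound 1 remains a limit of the assay and supplies no step: the limit of > 200000 nM in this assay, at which 1 of the 3 values shown sits.

Among these compounds, the single step changes both the halogen and its place on the phenyl ring at once, so the effect of either change alone remains unresolved. Also open, on these data alone, is whether an unsubstituted phenyl, an amine or a carboxylic acid at this place would stay within the scatter of compound 2.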